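Aryl swap on the sulfonamide nitrogen of an orexin-1 series

The source may hold more compounds than are shown below. What is called first, only, known or untested is meant among the compounds shown, and "the series" means these compounds.

Measured in a functional assay on CHO cells for inhibition of Orexin/Hypocretin receptor type 1 (Homo sapiens), read by FLIPR and calcium flux; on this read-out lower numbers stand for stronger inhibition and higher numbers for weaker inhibition:

Compound 1, `CCN(CC)C(=O)CN(c1cccc(N(C)C)c1C#N)S(=O)(=O)c1ccc(OC)c(OC)c1`: > 10000 nM
Compound 2, `CCN(CC)C(=O)CN(c1ccc(C)cc1)S(=O)(=O)c1ccccc1F`: > 10000 nM
Compound 3, `CCN(CC)C(=O)CN(c1ccc(C)cc1)S(=O)(=O)c1ccc(OC)cc1`: > 10000 nM

The value of compound 1 is a limit of the assay, not a number. The same is true of compound 2. The same is true of compound 3. All three compounds share a core in which a sulfonamide nitrogen carries an aryl group, a diethylamide-bearing chain and a sulfonyl sulfur that holds a second aryl group. Compound 1 therefore stands at the limit of > 10000 nM in this assay, at which 3 of the 3 values shown sit, and nothing separates it from its two neighbours.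

Among the compounds with values here, the one measured step, a step that the two limits leave unreadable from compound 2 to compound 3, changes the aryl group on the sulfonyl sulfur; both of its ends are limits, so its size cannot be read.

Compound 4, `CCN(CC)C(=O)CN(c1cc(N(C)C)ccc1OC)S(=O)(=O)c1ccc(OC)c(OC)c1`, differs from compound 1 on the other side of the core: 5-(dimethylamino)-2-methoxyphenyl in place of 2-cyano-3-(dimethylamino)phenyl on a sulfonamide nitrogen. Within the data shown here, no measured step touches this position, and the only step available is unreadable, so no direction beyond the scatter can be expected in this assay from the data at hand.

Compound 4 is therefore expected to remain weak, with an estimate of 20000 nM and a range from 5000 nM to 80000 nM, most likely reported again only as a limit. The step that the limit leaves unreadable from compound 1 to compound 4 is thus what is expected.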

Compound 4, half-maximal inhibitory concentration: > 10000 nM
Compound 4: only a limit was reported; the forecaster's own chance of this, stated with the estimate: 85%; the middle value does not contradict the limit.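

In this assay, compound 1 and compound 4 are both reported only as limits of the assay, not as numbers, so the swap of aryl group on the sulfonamide nitrogen between them has no readable size. All the compounds shown sit at one value: the limit of > 10000 nM in this assay, at which 4 of the 4 values shown sit.

Going by these compounds, what remains open is whether any change of aryl group on the shared core can give a readable number in this assay.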